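This account rests on a few compounds, and the source may have more. Where it says the series, first, only, none or still open, it means among the compounds named here.

Among the measured compounds shown here, compound 2 `CC(=O)c1ccc(OCCCCOc2ccc(C(=O)O)cc2C)c(C)c1O` stands lowest of the two numbers so far in an assay on HEK293 cells for positive allosteric modulation of metabotropic glutamate receptor 2 (Rattus norvegicus), read by thallium flux, with a stated time of 2.5 min (on this read-out higher numbers stand for an effect only at larger amounts of compound and lower numbers for an effect already at smaller amounts), giving 50 nM. Compound 1 `CCCC(=O)c1ccc(OCCCCOc2ccc(C(=O)O)cc2C)c(C)c1O` gives 104 nM in this assay; the step of a 2.1-fold lower number from compound 1 to compound 2 (0.32 log units; beyond the scatter) is hydrogen in place of ethyl on a saturated chain carbon bound to a carbonyl carbon. Compound 3 `Cc1cc(C(=O)O)ccc1OCCCCOc1ccc(C(=O)C(C)C)c(O)c1C` moves the other way: isopropyl in place of methyl on a carbonyl carbon. Carbon is added where compound 1 lost it, so the step of a 2.1-fold lower number from compound 1 to compound 2 (0.32 log units; beyond the scatter) read in reverse bears on it, and a modest rise in the number is expected, a 2.0-fold higher number from compound 2 to compound 3 (0.30 log units; within the scatter). Compound 3 is therefore estimated at 100 nM, between 40 nM and 250 nM.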

Compound 3, half-maximal effective concentration: 234 nM
Estimate against measurement, compound 3: 2.3-fold (0.37 log units) below, within the range that was stated.
By their numbers in this assay, from the lowest: compound 2; then compound 1; then compound 3.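

In this assay the branched isopropyl in place of methyl on a carbonyl carbon gives a 4.7-fold higher number from compound 2 to compound 3 (0.67 log units; beyond the scatter) and so goes further than the straight chain of compound 1 did. The shape of the group counts as well: isopropyl in place of propyl gives a 2.3-fold higher number from compound 1 to compound 3 (0.35 log units; beyond the scatter) as a second step upward, so the branched group stands above the straight one. Nothing measured here says why the number rises. On these data alone, whether cyclopropyl, a ring-bearing group, or the hydrogen of an aldehyde at this carbon would stand below compound 2 remains open.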